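A few compounds are considered here, and "the series" means these few. Any claim that something is new, unique, unknown or untested is made for them only; others in the source may bear on it.

Measured compounds:
- compound 1 `O=C(Nc1nc(-c2ccccc2)cn2cc(-c3ccccc3)nc12)c1ccc(F)cc1`: 1%
- compound 2 `O=C(Nc1nc(-c2ccccc2)cn2cc(-c3ccccc3)nc12)c1ccco1`: 10%
- compound 3 `O=C(Nc1nc(-c2ccccc2)cn2cc(-c3ccccc3)nc12)c1cccs1`: 5%

All three share one core and differ only in the group on the carbonyl carbon of the amide. In an assay on cells for displacement of a labelled ligand from adenosine receptor A1 (Homo sapiens), read by scintillation counting, with a stated time of 120 min, tested at 1 uM (on this read-out lower numbers stand for less inhibition and higher numbers for more inhibition at the one concentration tested (going by the name of the read-out)), compound 1 gives 1%, compound 2 gives 10% and compound 3 gives 5%. Compound 3 stands second highest of the three numbers: its nearest neighbour is compound 1, with a number 4 percentage points higher from compound 1 to compound 3 (within the scatter), and its furthest is compound 2, with a number 5 percentage points lower from compound 2 to compound 3 (within the scatter). The remaining step, a number 9 percentage points higher from compound 1 to compound 2 (within the scatter), is also within the scatter, so the three groups on the carbonyl carbon give numbers that cannot be told apart.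

Compound 4 `O=C(Nc1nc(-c2ccccc2)cn2cc(-c3ccccc3)nc12)c1cccnc1` is the next member of this series. It differs from compound 3 as follows: pyridin-3-yl in place of thiophen-2-yl on a carbonyl carbon. Among the compounds with values here, the steps that bear on this change are the three above, each exchanging the group on the carbonyl carbon, and none of them moved the number beyond the scatter. Compound 4 is therefore expected to give a step of a number 1 percentage points higher from compound 3 to compound 4 (within the scatter), that is, no step beyond the scatter. For compound 4 the estimate in this assay is 6%, with a range from 0% to 18%.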

Compound 4, a percentage reported as inhibition, at one concentration (the size of the read-out at that concentration, not a potency): 11%
Estimate against measurement, compound 4: 5 percentage points below; low and high end bracket the measured number.
By their numbers in this assay, from the lowest: compounds 1, 3, 2 and 4 (each within the scatter of the next).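

In this assay, pyridin-3-yl brings a six-membered aromatic ring with one ring nitrogen onto the carbonyl carbon, and the steps to it are a number 6 percentage points higher from compound 3 to compound 4 (within the scatter), a number 1 percentage points higher from compound 2 to compound 4 (within the scatter) and a number 10 percentage points higher from compound 1 to compound 4 (within the scatter). The earlier compounds shown here showed no step beyond the scatter among 4-fluorophenyl, furan-2-yl and thiophen-2-yl, and this result extends that to pyridin-3-yl, so all four aromatic groups at this position give numbers that cannot be told apart. No measurement is available that bears on this result.

As far as these compounds go, whether a group of another kind on the carbonyl carbon, such as a piperidin-4-yl amine, a carboxylic acid or a longer alkyl chain, would move the number beyond the scatter remains open. From the compounds shown here alone, all four compounds share one core, so the effect of a change elsewhere in it also remains open.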